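A few compounds are considered here, and "the series" means these few. Any claim that something is new, unique, unknown or untested is made for them only; others in the source may bear on it.

Three members of the series have numbers in a functional assay on DU-145 cells (Homo sapiens) for inhibition, read by trypan blue exclusion, with a stated time of 96 h; a higher number here means a weaker inhibitor of growth, a lower number a stronger inhibitor of growth. Compound 1 `CCOc1ccc(/C=C(/Sc2ccc(C)cc2)C(=O)c2ccc(Cl)cc2)cc1OC` gives 25000 nM. Compound 2 `CCOc1ccc(/C=C(\C(=O)c2ccc(Cl)cc2)S(=O)(=O)Cc2ccc(F)cc2)cc1OC` gives 50000 nM, and compound 3 `CCOc1ccc(/C=C(/SCc2ccc(C)cc2)C(=O)c2ccc(Cl)cc2)cc1OC` gives 25000 nM. Within the data shown here, compound 2 carries the highest of the three numbers, yet its nearest neighbour is compound 1, with a 2.0-fold higher number from compound 1 to compound 2 (0.30 log units; within the scatter), and its furthest is compound 3, with a 2.0-fold lower number from compound 2 to compound 3 (0.30 log units; within the scatter), so no member is separated from another beyond the scatter; the remaining step, no change at the digits printed from compound 1 to compound 3 (within the scatter), is equally flat.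

Compound 4 `O=C(/C(=C\c1ccc(Br)cc1)S(=O)(=O)Cc1ccc(F)cc1)c1ccc(Cl)cc1` differs from compound 2 at a place untouched by the three measured steps: 4-bromophenyl in place of 4-ethoxy-3-methoxyphenyl on a double-bonded chain carbon bound to a double-bonded chain carbon. Among the measured compounds shown here, each measured step alters the group on the sulfur, and none alters the aryl on the double-bonded chain carbon, so no measured step bears directly on this change; the only guidance is that every change tried so far, whatever its place, has stayed within the scatter. The expectation for compound 4 is therefore a number near that of compound 2, with a wide range to reflect the absence of any directly relevant step. Compound 4 is estimated at 50000 nM, between 15000 nM and 160000 nM. The step this expectation implies, no change at the digits printed from compound 2 to compound 4 (within the scatter), is expected to lie within the scatter.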

Compound 4, concentration for 50% growth inhibition: > 100000 nM
Compound 4: no number, only a limit; the forecaster's own chance of this, stated with the estimate: 30%; middle value at least 2.0-fold (0.30 log units) from the limit.
By their numbers in this assay, from the lowest: compounds 1, 3 and 2 (each within the scatter of the next). At a limit, above all of these: compound 4.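

In this assay compound 4 gives > 100000 nM, which is a limit of the assay and not a number. Among these compounds, this is the first reading for a change on a double-bonded chain carbon bound to a double-bonded chain carbon: 4-bromophenyl in place of 4-ethoxy-3-methoxyphenyl gives an at least 2.0-fold higher number from compound 2 to compound 4 (0.30 log units; that floor lies within the scatter), so the change brings no measured gain in growth inhibition, while the floor of the step does not by itself place it beyond the scatter. The series reaches the limit only with this change, and the true size of the step remains unknown: the limit of > 100000 nM in this assay, at which 1 of the 4 values shown sits.

The single swap removes the ethoxy and methoxy groups and introduces bromine together, so the compounds shown cannot assign the outcome to any one of these, nor say whether 4-bromophenyl would give the same result with the sulfanyl groups of compound 1 or compound 3. Also open, as far as these compounds go, is how this place responds to a different substituent on the phenyl ring, such as a hydroxyl group, an amine or a carboxylic acid.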